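Shortening the alkyne chain toward a shorter lipoxygenase inhibitor

A few compounds are considered here, and "the series" means these few. Any claim that something is new, unique, unknown or untested is made for them only; others in the source may bear on it.

The compounds measured in an assay on isolated protein for inhibition of Arachidonate 12-lipoxygenase (Sus scrofa) (on this read-out higher numbers stand for weaker inhibition and lower numbers for stronger inhibition), so far:
- compound 1 `CCCCCCCCC#CCSCc1cccc(CCC(=O)O)c1` — in this assay compound 1 gives > 10000 nM, which is a limit of the assay rather than a number.
- compound 2 `CCCCCCCCC#CCOCc1cccc(CCC(=O)O)c1` — compound 2 gives 10000 nM.
- compound 3 `CCCCCCCCCCC#CCOCc1cccc(CCC(=O)O)c1` — compound 3 gives 320 nM.

Compound 3 holds the lowest of the two numbers shown; the nearest is compound 2, and the step of a 31-fold lower number from compound 2 to compound 3 (1.49 log units; beyond the scatter) lies beyond the scatter. Compound 1 sits at the limit of > 10000 nM in this assay, at which 1 of the 3 values shown sits, so its relation to the others can only be stated as a limit.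

Compound 4 `CCCCCCC#CCOCc1cccc(CCC(=O)O)c1` differs from compound 3 in one place: hydrogen in place of butyl on a saturated chain carbon, six bonds along the chain from a triple-bonded carbon. Going by the values given here, the only measured step that bears on this change is a 31-fold lower number from compound 2 to compound 3 (1.49 log units; beyond the scatter), in which lengthening the chain by ethyl gave a large gain. The step to compound 4 runs the other way and removes more than that ethyl added, so compound 4 is expected to move in this assay to a higher number than compound 2, a step of a 78-fold higher number from compound 3 to compound 4 (1.89 log units; beyond the scatter). The estimate for compound 4 is 25000 nM, within a range of 5000 nM to 150000 nM, and a limit rather than a number is expected to be the more likely outcome.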

Compound 4, half-maximal inhibitory concentration: > 10000 nM
Compound 4 was reported as a limit (the forecaster's own chance of this, stated with the estimate: 65%); the middle value does not contradict the limit.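

In this assay, losing butyl on a saturated chain carbon, six bonds along the chain from a triple-bonded carbon, gives an at least 31-fold higher number from compound 3 to compound 4 (1.49 log units; beyond the scatter), a large step toward weaker inhibition. Compound 4 gives only a limit of the assay (> 10000 nM). From the compounds shown here alone, the remaining step reads a number no lower from compound 2 to compound 4 (the limit leaves the size open), so whether the shortest chain is any weaker than that of compound 2 stays unknown. The earlier compounds shown here showed the gain from adding ethyl to the chain; this result shows that going below that shorter chain brings no recovery, and that among the three oxygen-linked compounds only compound 3 gives a value clearly clear of the limit, which now limits what the shorter end of the series can show: (the limit of > 10000 nM in this assay, at which 2 of the 4 values shown sit).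

Going by these compounds, whether a longer chain than that of compound 3 would lower the number further or turn it back up remains open. Also open, on these data alone, is how a sulfur link would read on the longer chain of compound 3, and whether an amide could stand in for the carboxylic acid.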